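This account rests on a few compounds, and the source may have more. Where it says the series, first, only, none or still open, it means among the compounds named here.

Compound 1 `CC(C)[C@H](NC(=O)CCN(C)C)c1cccc(F)c1N1CCN(C(=O)[C@@H]2CN(C(C)C)C[C@H]2c2cc(F)ccc2F)CC1` gives 2050 nM in an assay on HEK293 cells for displacement of a labelled ligand from Melanocortin receptor 4 (Homo sapiens); a lower number here means a stronger inhibitor, a higher number a weaker inhibitor.
Compound 2 `CC(C)[C@H](NC(=O)CCN(C)C)c1cccc(F)c1N1CCN(C(=O)[C@@H]2CN(C(C)C)C[C@H]2c2cccc(Cl)c2)CC1` gives 370 nM in this assay.
Compound 3 `Cc1ccc(N2CCN(C(=O)[C@@H]3CN(C4CCOCC4)C[C@H]3c3ccc(Cl)cc3)CC2)c([C@@H](NC(=O)CCN)C(C)C)c1` gives 2.2 nM in this assay.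

Compound 2 stands second highest of the three numbers in this assay. Its nearest neighbour is compound 1, and the step of a 5.5-fold lower number from compound 1 to compound 2 (0.74 log units; beyond the scatter) is the only one that touches a single position. Among the compounds with values here, compound 3 lies far lower, and no single-change step connects it to compound 2.

Compound 4 `CC(C)[C@H](NC(=O)CCN(C)C)c1cccc(F)c1N1CCN(C(=O)[C@@H]2CN(C(C)C)C[C@H]2c2cccc(F)c2)CC1` differs from compound 2 by fluoro in place of chloro on an aromatic carbon. The step from compound 1 to compound 2 bears only loosely on this change, since it swapped a whole halogen pattern rather than one halogen for another. A modest rise in number is expected for compound 4, estimated at 800 nM with a range of 300 nM to 2500 nM, which means an expected step of a 2.2-fold higher number from compound 2 to compound 4 (0.33 log units; beyond the scatter).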

Compound 4, inhibition constant: 560 nM
Estimate against measurement, compound 4: 1.4-fold (0.15 log units) above; low and high end bracket the measured number.
By their numbers in this assay, from the lowest: compound 3; then compounds 2 and 4 (each within the scatter of the next); then compound 1.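

Exchanging chloro for fluoro on this aromatic carbon gives a 1.5-fold higher number from compound 2 to compound 4 (0.18 log units; within the scatter), so 3-chlorophenyl and 3-fluorophenyl cannot be told apart here. The step of a 3.7-fold lower number from compound 1 to compound 4 (0.56 log units; beyond the scatter) isolates a single hydrogen for fluoro exchange, showing that this change alone, with no chlorine involved, moves the number beyond the scatter. Nothing available explains either step.

On these data alone, whether methoxy, trifluoromethyl or plain hydrogen on this aromatic carbon would hold the number remains open. So does whether the chloro to fluoro exchange would behave alike on the core of compound 3.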